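Replacing the para nitrile with fluorine on the benzoyl ring

A few compounds are considered here, and "the series" means these few. Any claim that something is new, unique, unknown or untested is made for them only; others in the source may bear on it.

Compound 3 `N#Cc1ccc(C(=O)NNC(=O)c2ccc(S(N)(=O)=O)cc2)cc1` gives 16100 nM in an assay on cells for inhibition of Amine oxidase [flavin-containing] A (Homo sapiens), read by fluorescence and spectrophotometry, using microsomes, with a stated time of 20 min (a higher number here means a weaker inhibitor, a lower number a stronger inhibitor), and stands second highest of the three numbers: compound 2 `NS(=O)(=O)c1ccc(C(=O)NNC(=O)c2ccc(Cl)c(Cl)c2)cc1` gives 13600 nM, within the scatter of it, while compound 1 `NS(=O)(=O)c1ccc(C(=O)NNC(=O)c2ccccc2)cc1` gives 62800 nM, the step of a 3.9-fold lower number from compound 1 to compound 3 (0.59 log units; beyond the scatter) lying beyond the scatter. Compound 4 `NS(=O)(=O)c1ccc(C(=O)NNC(=O)c2ccc(F)cc2)cc1` differs from compound 3 by fluoro in place of cyano on an aromatic carbon. The bearing steps are a 3.9-fold lower number from compound 1 to compound 3 (0.59 log units; beyond the scatter) and a 4.6-fold lower number from compound 1 to compound 2 (0.66 log units; beyond the scatter), both modest gains over the unsubstituted ring. The nitrile's gain is removed here; whether fluoro recovers part of it is not shown by any measured pair. Compound 4 is therefore expected to give a higher number, the step of a 2.2-fold higher number from compound 3 to compound 4 (0.34 log units; beyond the scatter) being the estimate, with a value of 35000 nM and a range from 12000 nM to 100000 nM.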

Compound 4, half-maximal inhibitory concentration: 39600 nM
Compound 4: middle estimate off by 1.1-fold (0.05 log units), on the low side; low and high end bracket the measured number.
By their numbers in this assay, from the lowest: compounds 2 and 3 (each within the scatter of the next); then compounds 4 and 1 (each within the scatter of the next).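

At this aromatic carbon in this assay, not every replacement of hydrogen carries a gain: fluoro cannot be told apart from hydrogen, with a 1.6-fold lower number from compound 1 to compound 4 (0.20 log units; within the scatter) within the scatter, while a 2.5-fold higher number from compound 3 to compound 4 (0.39 log units; beyond the scatter) separates fluoro from cyano. The 4-fluorophenyl also falls short of the 3,4-dichlorophenyl, with a 2.9-fold higher number from compound 2 to compound 4 (0.46 log units; beyond the scatter) beyond the scatter. No measurement given here accounts for these differences. As far as these compounds go, whether an amine or a carboxylic acid at this carbon would match cyano remains open, as does whether a single chlorine here would match the 3,4-dichlorophenyl.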